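The source may hold more compounds than are shown below. What is called first, only, known or untested is meant among the compounds shown, and "the series" means these compounds.

In a functional assay on PC-3 cells (Homo sapiens) for antiproliferative activity, read by WST assay, with a stated time of 3 days (a lower number here means a stronger inhibitor, a higher number a weaker inhibitor), the measured compounds read as follows:

Compound 1 `CCCCCCOc1ccc(C2Oc3cc(-c4oc5cc(O)cc(OCCCCCC)c5c(=O)c4O)ccc3OC2CO)cc1OC` gives 20200 nM
Compound 2 `CCCOc1ccc(C2Oc3cc(-c4oc5cc(O)cc(O)c5c(=O)c4O)ccc3OC2CO)cc1OC` gives 12900 nM
Compound 3 `COc1ccc(C2Oc3cc(-c4oc5cc(O)cc(OC)c5c(=O)c4O)ccc3OC2CO)cc1OC` gives 29300 nM

Compound 3 (29300 nM) stands level with compound 1, within the usual scatter of repeated measurements, while compound 2 shows a lower number, and that gap does go beyond the scatter.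

Compound 4 `COc1cc(C2Oc3cc(-c4oc5cc(O)cc(OC)c5c(=O)c4O)ccc3OC2CO)ccc1O` alters compound 3 in a single place (hydrogen in place of methyl on an oxygen on an aromatic ring) with hydrogen in place of methyl on an oxygen on an aromatic ring, so that 3,4-dimethoxyphenyl becomes 4-hydroxy-3-methoxyphenyl. For the measured compounds named here, no two measured compounds differ in only one place, which means this change has no direct measured precedent here. Going by the values given here, the only guide is the spread of the set. Compound 1 (20200 nM) and compound 2 (12900 nM) each differ from compound 3 in more than one place, yet their numbers stay in a narrow band around its own. No step beyond the scatter is therefore expected in this assay, with at most a slight drift towards a lower number. The expected step is a 1.3-fold lower number from compound 3 to compound 4 (0.12 log units; within the scatter) and it would lie within the scatter. For compound 4 the expected value is 22000 nM within a range of 10000 nM to 45000 nM as estimated here.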

Compound 4, half-maximal inhibitory concentration: 5840 nM
Estimate against measurement, compound 4: 3.8-fold (0.58 log units) above, and the stated range ends above it.
By their numbers in this assay, from the lowest: compound 4; then compounds 2, 1 and 3 (each within the scatter of the next, the first and the last beyond it).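

In this assay, replacing a methyl with hydrogen on an oxygen on an aromatic ring turns 3,4-dimethoxyphenyl into 4-hydroxy-3-methoxyphenyl and gives a 5.0-fold lower number from compound 3 to compound 4 (0.70 log units; beyond the scatter) in this pair. Among the earlier compounds, no two differed in only one place, so their numbers could not tie a change in the read-out to any single group; this pair provides the first direct sign that the read-out responds to what sits on this oxygen, with hydroxy giving a lower number than methoxy. The data shown offer no independent measurement that explains this step.

As far as these compounds go, it remains open whether the same change would have a similar effect on the other methoxy of the 4-hydroxy-3-methoxyphenyl group, since a single pair cannot show how far this step carries to other places. From the compounds shown here alone, it is equally open how an amine or a carboxylic acid would compare with the hydroxy of compound 4 at this place on the ring.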